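This account rests on a few compounds, and the source may have more. Where it says the series, first, only, none or still open, it means among the compounds named here.

Measured compounds:
Compound 1 `Cc1c(/C=C/[S+](C)[O-])oc2ccccc2c1=O` gives 7200 nM in a functional assay on DLD-1 cells (Homo sapiens) for cytotoxicity, with a stated time of 48 h; a higher number here means a weaker inhibitor, a lower number a stronger inhibitor.
Compound 2 `C[S+]([O-])/C=C/c1cc(=O)c2cc(Cl)ccc2o1` gives 6500 nM in this assay.
Compound 3 `COc1cccc2oc(/C=C/[S+](C)[O-])cc(=O)c12` gives > 10000 nM in this assay, and this is a limit of the assay rather than a number.

All three share one core with a methylsulfinylvinyl arm and differ only in the substituent on the benzene part of the fused system. Compound 2 carries the lowest of the two numbers given, but compound 1 sits so close to it that the two cannot be told apart within the usual scatter. Compound 3 reaches only the limit (the limit of > 10000 nM in this assay, at which 1 of the 3 values shown sits).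

The step to be followed goes from compound 2 to compound 4 `CCCCC(=O)Oc1ccc2oc(/C=C/[S+](C)[O-])cc(=O)c2c1`, and the change is this: (butylcarbonyl)oxy in place of chloro on an aromatic carbon. Within the data shown here, no such step has been measured here, so no directly comparable size is known. Among the measured compounds shown here, since every value so far is weak, the expectation for compound 4 is a step in this assay of about the scatter or a little beyond it, toward a weaker inhibitor, that is a 1.2-fold higher number from compound 2 to compound 4 (0.09 log units; within the scatter). Compound 4 is therefore expected to give about 8000 nM, between 3000 nM and 20000 nM.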

Compound 4, half-maximal inhibitory concentration: 6700 nM
Compound 4: middle estimate off by 1.2-fold (0.08 log units), on the high side; measured number inside the range.
By their numbers in this assay, from the lowest: compounds 2, 4 and 1 (each within the scatter of the next). At a limit, above all of these: compound 3.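

Putting (butylcarbonyl)oxy in place of chloro on this aromatic carbon gives a 1.0-fold higher number from compound 2 to compound 4 (0.01 log units; within the scatter) in this assay. The earlier compounds shown here could not show this: the position accepts a far larger group, seven heavy atoms instead of one and with a double bond and two hydrogen-bond acceptors that chloro lacks, and the number cannot be told apart from that of the chloro compound. No measurement shown here speaks to the reason for this result.

As far as these compounds go, it stays open whether an amine, a carboxylic acid or a longer chain on this same aromatic carbon would give a step beyond the scatter. Also open, from the compounds shown here alone, is what a change to the methylsulfinylvinyl arm, such as an ethyl group on the sulfur, would do.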